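A few compounds are considered here, and "the series" means these few. Any claim that something is new, unique, unknown or untested is made for them only; others in the source may bear on it.

Three compounds share one core and differ only in the aryl group on a saturated ring carbon. Compound 1 `CCNC(=O)C1=C(C)NC(=O)NC1c1ccco1` was tested in an assay on membranes from HeLa cells for displacement of a labelled ligand from adenosine receptor A3 (Homo sapiens), read by scintillation counting, with a stated time of 180 min, tested at 1 uM (on this read-out lower numbers stand for less inhibition and higher numbers for more inhibition at the one concentration tested (going by the name of the read-out)), where compound 1 gives 3%. Compound 2 `CCNC(=O)C1=C(C)NC(=O)NC1c1ccoc1` gives 1%, and compound 3 `CCNC(=O)C1=C(C)NC(=O)NC1c1ccsc1` gives 1%. The steps among them are all small: a number 2 percentage points lower from compound 1 to compound 2 (within the scatter), a number 2 percentage points lower from compound 1 to compound 3 (within the scatter) and no change at the digits printed from compound 2 to compound 3 (within the scatter). Compound 1 therefore stands among three numbers that cannot be told apart, and nothing in this set marks any of the three as different from the others.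

Compound 4 `CCC(C)OC(=O)C1=C(C)NC(=O)NC1c1ccco1` has not yet been measured. It differs from compound 1 in sec-butoxy in place of ethylamino on a carbonyl carbon. Going by the values given here, none of the measured steps bears directly on this change: each of them exchanges the aryl group on the saturated ring carbon, while the carbonyl substituent stays the same. What they do show is that, across the variation tried so far, the numbers stay low and close together.

Among the compounds with values here, with no step of the relevant kind to lean on, the expectation for compound 4 is that its number stays near that of compound 1, with an expected step of no change at the digits printed from compound 1 to compound 4 (within the scatter), no change beyond the scatter. The estimate for compound 4 is 3%, expected to fall between -6% and 15%.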

Compound 4, a percentage reported as inhibition, at one concentration (the size of the read-out at that concentration, not a potency): 3%
Beside the measured number, compound 4's estimate shows no gap at the digits printed; measured number inside the range.
By their numbers in this assay, from the lowest: compounds 2, 3, 1 and 4 (each within the scatter of the next).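

Going by these compounds alone, the exchange on the carbonyl carbon is the first in this set to leave the aryl group in place, and in this assay the replacement of ethylamino by sec-butoxy gives no change at the digits printed from compound 1 to compound 4 (within the scatter). This change swaps an ethylamino group with 1 hydrogen-bond donor and 3 heavy atoms for a branched sec-butoxy group with 1 hydrogen-bond acceptor and 5 heavy atoms, so the low numbers seen so far now hold for a change at this second place as well as for changes of the aryl group. No measurement shown offers an explanation for this result, and with every number at the low end of the read-out, the step does not show whether the carbonyl substituent matters for this receptor.

Still open, going by these compounds, is whether any other group on this carbonyl carbon, such as a benzyloxy group, a longer alkoxy chain, a free carboxylic acid or a cyclic amine, would lift the number clear of the scatter. Also open, on these data alone, is whether sec-butoxy would give the same result with furan-3-yl or thiophen-3-yl on the saturated ring carbon.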